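A few compounds are considered here, and "the series" means these few. Any claim that something is new, unique, unknown or untested is made for them only; others in the source may bear on it.

Three related lactones have been examined in a functional assay on HL-60 cells (Homo sapiens) for cytotoxicity, read by WST assay, with a stated time of 48 h; on this read-out higher numbers stand for an effect only at larger amounts of compound and lower numbers for an effect already at smaller amounts. Compound 1 `COc1cccc(C[C@H]2C(=O)OC[C@@H]2Cc2ccccc2)c1` gives 66000 nM. Compound 2 `O=C1OC[C@H](Cc2ccccc2)[C@H]1Cc1cccc(OC(F)(F)F)c1` differs from compound 1 only by trifluoromethyl in place of methyl on an oxygen on an aromatic ring; in this assay compound 2 gives 34000 nM. The resulting step, a 1.9-fold lower number from compound 1 to compound 2 (0.29 log units; within the scatter), stays inside the usual scatter. Compound 3 `COc1ccc(C[C@H]2C(=O)OC[C@@H]2Cc2ccccc2)cc1` is built from the same atoms as compound 1 joined differently; the difference between the two cores is not broken down here. In this assay compound 3 gives 67000 nM. Compound 4 `O=C1OC[C@H](Cc2ccccc2)[C@H]1Cc1ccc(OC(F)(F)F)cc1` differs from compound 3 by trifluoromethyl in place of methyl on an oxygen on an aromatic ring, the same change seen between compound 1 and compound 2. Compound 4 is therefore expected to give about 36000 nM, most likely between 15000 nM and 85000 nM, because the earlier step of a 1.9-fold lower number from compound 1 to compound 2 (0.29 log units; within the scatter) stayed within the scatter. The step expected from compound 3 is a 1.9-fold lower number from compound 3 to compound 4 (0.27 log units; within the scatter).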

Compound 4, half-maximal effective concentration: 27000 nM
For compound 4 the middle estimate is 1.3-fold (0.12 log units) above the measured one, and the stated range covers the measured number.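

In this assay, trifluoromethyl in place of methyl on an oxygen on an aromatic ring gives a 2.5-fold lower number from compound 3 to compound 4 (0.39 log units; beyond the scatter) on the second core, and this step cannot be told apart from the one on the first core: the same change on two cores in this assay, a 1.9-fold lower number (0.29 log units; within the scatter) from compound 1 to compound 2 and a 2.5-fold lower number (0.39 log units; beyond the scatter) from compound 3 to compound 4, 1.3-fold (0.11 log units) apart, within the scatter of two such steps. The change therefore carries across these two cores with a step of similar size in this one assay. This does not show that it would carry to any other core, and it says nothing about why the numbers sit where they do. The compounds shown leave open what other groups on that oxygen, such as a longer chain or one bearing an amine or a carboxylic acid, would give.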